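Swapping 2-methylphenyl for 4-bromophenyl on the shared core

This account rests on a few compounds, and the source may have more. Where it says the series, first, only, none or still open, it means among the compounds named here.

Compound 3 `Cc1ccccc1NC(=S)N/N=C/c1ccc2ccccc2n1` gives only a limit in a functional assay on SGC-7901 cells (Homo sapiens) for antiproliferative activity, read by sulforhodamine B assay, with a stated time of 72 h (a lower number here means a stronger inhibitor, a higher number a weaker inhibitor), with > 100000 nM as its reading. Compound 1 `Cc1cccc(NC(=S)N/N=C/c2ccc3ccccc3n2)c1` also stands at a limit, with > 100000 nM as its reading. Only compound 2 `N#Cc1ccc(NC(=S)N/N=C/c2ccc3ccccc3n2)cc1` reaches a true number, with 23700 nM as its reading.

Compound 4 `S=C(N/N=C/c1ccc2ccccc2n1)Nc1ccc(Br)cc1` carries 4-bromophenyl in place of the 2-methylphenyl of compound 3 on an amide-type nitrogen, and 4-bromophenyl in place of 2-methylphenyl on an amide-type nitrogen counts that change. Among the measured compounds shown here, the steps that bear on it are an at least 4.2-fold lower number from compound 1 to compound 2 (0.62 log units; beyond the scatter) and an at least 4.2-fold higher number from compound 2 to compound 3 (0.62 log units; beyond the scatter) in turn, both beyond the scatter and both tied to the 4-cyanophenyl of compound 2. That single case is thin support, since 4-bromophenyl is a different group. The expected step is an at least 4.0-fold lower number from compound 3 to compound 4 (0.60 log units; beyond the scatter) in this assay and points towards a lower number of modest size. A reading at the limit stays possible because of the limit of > 100000 nM in this assay, at which 2 of the 3 values shown sit, and the range is wide for that reason. The estimate for compound 4 is 25000 nM with an expected range from 6000 nM at the low end to 100000 nM at the high end.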

Compound 4, half-maximal inhibitory concentration: 69400 nM
Estimate against measurement, compound 4: 2.8-fold (0.44 log units) below, and the stated range covers the measured number.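

In this assay, among the compounds shown here, compound 4 joins compound 2 as the only compounds with a true number, so both 4-substituted phenyl groups on this amide-type nitrogen give a reading, while both methylphenyl compounds stay at a limit. The comparisons with the methylphenyl compounds, an at least 1.4-fold lower number from compound 3 to compound 4 (0.15 log units; that floor lies within the scatter) and an at least 1.4-fold lower number from compound 1 to compound 4 (0.15 log units; that floor lies within the scatter), are only floors because compound 1 and compound 3 sit at a limit: the limit of > 100000 nM in this assay, at which 2 of the 4 values shown sit. For the compounds shown here, the one step between two true numbers is a 2.9-fold higher number from compound 2 to compound 4 (0.47 log units; beyond the scatter), which shows that bromo in place of cyano on an aromatic carbon shifts the reading even though the phenyl ring stays.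

The compounds shown cannot separate the kind of group from where it sits on the ring, since both methyl groups sit elsewhere than the bromo and cyano. From the compounds shown here alone, how an amine or a carboxylic acid in place of the bromo would read remains open.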